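A few compounds are considered here, and "the series" means these few. Any claim that something is new, unique, unknown or untested is made for them only; others in the source may bear on it.

Measured so far in an assay on microsomes from brain for inhibition of Fatty-acid amide hydrolase 1 (Rattus norvegicus), read by fluorescence and HPLC, with a stated time of 60 min; a higher number here means a weaker inhibitor, a lower number a stronger inhibitor:
compound 1 `CCCCCCCCc1ccc(OCC(=O)Cn2nnc(-c3ccc(Cl)cc3)n2)cc1`: 35 nM
compound 2 `CCCCCCCCc1ccc(OCC(=O)Cn2nnc(-c3cccc(C(=O)OC)c3)n2)cc1`: 34 nM
compound 3 `CCCCCCCCc1ccc(OCC(=O)Cn2nnc(-c3ccc(S(=O)(=O)N(C)C)cc3)n2)cc1`: 590 nM

In this assay compound 1 gives 35 nM, the second highest of the three numbers; the nearest is compound 2 (a 1.0-fold lower number from compound 1 to compound 2 (0.01 log units; within the scatter)), the furthest compound 3 (a 17-fold higher number from compound 1 to compound 3 (1.23 log units; beyond the scatter)). Compound 4 `CCCCCCCCc1ccc(OCC(=O)Cn2nnc(-c3cccc(S(=O)(=O)N(C)C)c3)n2)cc1` differs from compound 1 by 3-(dimethylsulfamoyl)phenyl in place of 4-chlorophenyl on an aromatic carbon. Going by the values given here, two measured steps bear on this change: a 17-fold higher number from compound 1 to compound 3 (1.23 log units; beyond the scatter) and a 17-fold higher number from compound 2 to compound 3 (1.24 log units; beyond the scatter), both large and in the weakening direction, whereas a 1.0-fold lower number from compound 1 to compound 2 (0.01 log units; within the scatter) shows that a different group on the phenyl ring can leave the number unchanged. Among the compounds with values here, no measured pair tests the dimethylsulfamoyl group at this position. A weakening step is therefore expected for compound 4, roughly an 8.6-fold higher number from compound 1 to compound 4 (0.93 log units; beyond the scatter), though with wide uncertainty. The estimate for compound 4 in this assay is 300 nM, range 80 nM to 1200 nM.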

Compound 4, half-maximal inhibitory concentration: 420 nM
The estimate for compound 4 lay 1.4-fold (0.15 log units) below the measured number, and the stated range covers the measured number.
By their numbers in this assay, from the lowest: compounds 2 and 1 (each within the scatter of the next); then compounds 4 and 3 (each within the scatter of the next).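

In this assay, 3-(dimethylsulfamoyl)phenyl also gives a large weakening, with a 12-fold higher number from compound 1 to compound 4 (1.08 log units; beyond the scatter) and, in a single swap of methoxycarbonyl for dimethylsulfamoyl, a 12-fold higher number from compound 2 to compound 4 (1.09 log units; beyond the scatter) on the same ring.
The two dimethylsulfamoyl isomers are not separated, with a 1.4-fold lower number from compound 3 to compound 4 (0.15 log units; within the scatter), so in compounds 3 and 4 the loss accompanies the group at either attachment point.
No measurement here explains this loss.

Still open, from the compounds shown here alone, is whether a primary sulfonamide, a carboxylic acid or an amine on this phenyl ring would stay close to compound 1 or follow compounds 3 and 4. Also open, going by these compounds, is whether the chloro of compound 1 and the methoxycarbonyl of compound 2 depend on their attachment points.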